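The source may hold more compounds than are shown below. What is called first, only, known or untested is meant among the compounds shown, and "the series" means these compounds.

For the measured compounds named here, in a functional assay on MDA-MB-231 cells (Homo sapiens) for cytotoxicity, read by MTT assay, with a stated time of 48 h (a lower number here means a stronger inhibitor, a higher number a weaker inhibitor), compound 3 `CC(C)n1c(/C=C2/C(=O)Nc3ccc(Cl)cc32)nc2ccccc21` gives 25100 nM, the only true number in the set so far. Compound 1 `CCn1c(/C=C2/C(=O)Nc3ccc(F)cc32)nc2ccccc21` reads > 50000 nM, which is a limit. Compound 2 `CCn1c(/C=C2/C(=O)Nc3ccccc32)nc2ccccc21` reads > 50000 nM, also a limit. Compound 4 `CCn1c(/C=C2/C(=O)Nc3ccc(Cl)cc32)nc2ccccc21` differs from compound 3 by hydrogen in place of methyl on a saturated chain carbon bound to an aromatic nitrogen and a saturated chain carbon, hydrogen in place of methyl on a saturated chain carbon, which reads as isopropyl to ethyl. Going by the values given here, the one measured step is a step that the two limits leave unreadable from compound 1 to compound 2. Among the compounds with values here, the only guide is the limit of > 50000 nM in this assay, at which 2 of the 3 values shown sit, reached by both ethyl compounds, compound 1 and compound 2, though each differs from compound 4 elsewhere on the core. The estimated step is a 1.4-fold higher number from compound 3 to compound 4 (0.14 log units; within the scatter), so no move beyond the scatter is expected in this assay, although the limit may be reached. For compound 4 the estimated value is 35000 nM, with an expected range of 15000 nM to 50000 nM.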

Compound 4, half-maximal inhibitory concentration: 37500 nM
Compound 4: the middle estimate sits 1.1-fold (0.03 log units) below what was measured; measured number inside the range.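

In this assay the change from isopropyl to ethyl gives a 1.5-fold higher number from compound 3 to compound 4 (0.17 log units; within the scatter) and so leaves the number within the scatter at this position. With ethyl kept, chloro gives an at least 1.3-fold lower number from compound 2 to compound 4 (0.12 log units; that floor lies within the scatter) against hydrogen and an at least 1.3-fold lower number from compound 1 to compound 4 (0.12 log units; that floor lies within the scatter) against fluoro as well. Both are floors only, since compound 1 and compound 2 each stand at a limit: the limit of > 50000 nM in this assay, at which 2 of the 4 values shown sit.

Open, on these data alone, is whether a longer chain or an amine in place of ethyl would move the number beyond the scatter. Also open, as far as these compounds go, is what a methoxy group in place of chloro would do.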